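Propyl Gives Way to Phenyl at the Ring Nitrogen

The source may report more compounds than this note shows. Statements on the series, on what has been measured and on what is new or still open speak of the compounds shown alone.

Compound 1, with the structure `CCOC(=O)c1cn(C)c2cc(Cl)ccc2c1=O`, was tested in a functional assay on PC-3 cells (Homo sapiens) for cytotoxicity, read by MTT assay, with a stated time of 24 h; a lower number here means a stronger inhibitor, a higher number a weaker inhibitor. In this assay compound 1 reaches only the limit > 50000 nM, which is a limit of the assay and not a number. Compound 2, with the structure `CCCCn1cc(C(=O)OCC)c(=O)c2ccc(Cl)cc21`, carries propyl in place of hydrogen on a saturated chain carbon bound to an aromatic nitrogen, and in this assay compound 2 gives 41700 nM. This is the only number shown; the one further value is a limit. The measured step of an at least 1.1-fold lower number from compound 1 to compound 2 (0.07 log units; that floor lies within the scatter) is therefore read against (the limit of > 50000 nM in this assay, at which 1 of the 2 values shown sits), and it tells little about the direction of change.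

Compound 3, with the structure `CCOC(=O)c1cn(Cc2ccccc2)c2cc(Cl)ccc2c1=O`, differs from compound 2 as phenyl in place of propyl on a saturated chain carbon bound to an aromatic nitrogen. Going by the values given here, only the single measured step bears on this change, and that step did not rise above the scatter. Compound 3 is therefore expected to stay close to compound 2, with an estimate of 30000 nM between 10000 nM and 100000 nM. The step this estimate means, a 1.4-fold lower number from compound 2 to compound 3 (0.14 log units; within the scatter), is expected to be no larger than the scatter.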

Compound 3, half-maximal inhibitory concentration: 27900 nM
For compound 3 the middle estimate is 1.1-fold (0.03 log units) above the measured one; measured number inside the range.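

Setting phenyl in place of propyl on a saturated chain carbon bound to an aromatic nitrogen brings the first ring to this place, and in this assay the step reads a 1.5-fold lower number from compound 2 to compound 3 (0.17 log units; within the scatter). A six-membered aromatic ring of carbon only is therefore accepted here, but the change in size and shape of the group, from butyl to benzyl, gives no difference that can be told from the scatter. Read over the whole change from the shortest substituent, the step is an at least 1.7-fold lower number from compound 1 to compound 3 (0.25 log units; that floor lies within the scatter), a wider floor than the earlier one, though still not a step beyond the scatter. Compound 1 stands at a limit of the assay and not at a number, so that step has a floor and no measured size: the limit of > 50000 nM in this assay, at which 1 of the 3 values shown sits.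

The compounds shown leave open whether any group at this place can move the number beyond the scatter, and what the ethyl ester and the chlorine contribute, since both stay the same throughout. An amine or a carboxylic acid at the end of the chain, or a longer chain carrying the phenyl, would put that question to the same core.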